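The source may report more compounds than this note shows. Statements on the series, on what has been measured and on what is new or still open speak of the compounds shown alone.

In an assay on isolated protein for inhibition of RAC-beta serine/threonine-protein kinase (Homo sapiens), read by radiometric assay and filter binding (on this read-out lower numbers stand for stronger inhibition and higher numbers for weaker inhibition), compound 2 `NCC1CCN(c2ncnc3[nH]ccc23)CC1` gives 770 nM, the second highest of three numbers recorded. In this assay compound 1 `NCC1(Cc2ccc(Cl)cc2)CCN(c2ncnc3[nH]ccc23)CC1` gives 5 nM, and compound 3 `Cc1nc2c(N3CCC(N)CC3)ncnc2[nH]1` gives 110000 nM. Compound 4 `NC(c1ccc(Cl)cc1)C1CCN(c2ncnc3[nH]ccc23)CC1` differs from compound 2 by 4-chlorophenyl in place of hydrogen on a saturated chain carbon bound to an amine nitrogen and a saturated ring carbon. Going by the values given here, the one measured step that bears on this is a 150-fold higher number from compound 1 to compound 2 (2.19 log units; beyond the scatter), where a 4-chlorobenzyl group was removed from a saturated ring carbon; read in reverse, adding a chlorinated aromatic group brought a large gain. The attachment point in compound 4 is a saturated chain carbon rather than a ring carbon, so the gain is expected to be smaller. For compound 4 the expected step is a 9.6-fold lower number from compound 2 to compound 4 (0.98 log units; beyond the scatter). The estimate for compound 4 in this assay is 80 nM, within a range from 10 nM to 600 nM.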

Compound 4, half-maximal inhibitory concentration: 25 nM
Beside the measured number, compound 4's estimate is 3.2-fold (0.51 log units) above it, within the range that was stated.
By their numbers in this assay, from the lowest: compound 1; then compound 4; then compound 2; then compound 3.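

In this assay there is a 31-fold lower number from compound 2 to compound 4 (1.49 log units; beyond the scatter) when 4-chlorophenyl enters on the saturated chain carbon bound to an amine nitrogen and a saturated ring carbon. A large gain from a chlorinated aromatic group is therefore not confined to the saturated ring carbon that carries 4-chlorobenzyl in compound 1, since this chain carbon gives one too. No measurement here accounts for the gain. From the compounds shown here alone, what a plain phenyl or a methyl group would do on this chain carbon stays open, and so does how much of the gain belongs to the chlorine.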